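The source may report more compounds than this note shows. Statements on the series, on what has been measured and on what is new or still open speak of the compounds shown alone.

Among the compounds with values here, compound 2, with the structure `Cc1cc(O)c(C2=NN(c3ccc(S(N)(=O)=O)cc3)C(c3ccccc3Cl)C2)cc1Cl`, is one of two compounds measured in a functional assay on MDA-MB-468 cells (Homo sapiens) for antiproliferative activity, with a stated time of 48 h; on this read-out lower numbers stand for stronger inhibition of growth and higher numbers for weaker inhibition of growth. In this assay compound 2 gives 2220 nM. Compound 1, with the structure `Cc1cc(O)c(C2=NN(c3ccc(S(N)(=O)=O)cc3)C(c3ccccc3O)C2)cc1Cl`, gives 2580 nM in this assay. Compound 2 thus has the lower of the two numbers, but the gap lies within the scatter, so it cannot be called the stronger one. Within the data shown here, the only measured step, a 1.2-fold lower number from compound 1 to compound 2 (0.07 log units; within the scatter), came from putting chloro in place of hydroxy on an aromatic carbon, and it stayed within the scatter.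

Compound 3, with the structure `Cc1cc(O)c(C2=NN(c3ccc(S(N)(=O)=O)cc3)C(/C=C/c3ccccc3)C2)cc1Cl`, has not yet been measured in this assay. The change from compound 2 is 2-phenylethenyl in place of 2-chlorophenyl on a saturated ring carbon. Among the measured compounds shown here, this is a change of a different kind from the one measured step, which swapped one small group for another on the same ring; no measured step bears directly on replacing a 2-chlorophenyl group by a 2-phenylethenyl group. For the measured compounds named here, with only one step known, and that one within the scatter, the expectation for compound 3 is a step of no clear direction, a 1.1-fold higher number from compound 2 to compound 3 (0.05 log units; within the scatter), with a wide range. Compound 3 is therefore estimated at 2500 nM in this assay, with a range from 900 nM to 7000 nM.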

Compound 3, concentration for 50% growth inhibition: 3940 nM
For compound 3 the middle estimate is 1.6-fold (0.20 log units) below the measured one, and the stated range covers the measured number.
By their numbers in this assay, from the lowest: compounds 2, 1 and 3 (each within the scatter of the next).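

Compound 3 is the first of these compounds in which the whole group on the saturated ring carbon changes, not just one small group on its ring. In this assay, 2-phenylethenyl in place of 2-chlorophenyl gives a 1.8-fold higher number from compound 2 to compound 3 (0.25 log units; within the scatter) and, in place of 2-hydroxyphenyl, it gives a 1.5-fold higher number from compound 1 to compound 3 (0.18 log units; within the scatter) on the same carbon. Both steps lie within the scatter, so among these three compounds a double bond outside the aromatic ring can enter this group, and the phenyl ring can lose its chloro or hydroxy substituent, without a difference this read-out can resolve; no measurement of any property of these groups is at hand to explain the numbers.

Every group shown on this carbon still carries a phenyl ring, so it remains open what a saturated group such as a cyclohexyl ring or a longer alkyl chain, or a chain ending in an amine, would do here. The 4-sulfamoylphenyl group and the 5-chloro-2-hydroxy-4-methylphenyl group are the same throughout, so these compounds also say nothing about a carboxylic acid in place of the sulfamoyl group.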